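The source may report more compounds than this note shows. Statements on the series, on what has been measured and on what is new or still open speak of the compounds shown alone.

Measured so far in a functional assay on SGC-7901 cells (Homo sapiens) for antiproliferative activity, read by MTT assay, with a stated time of 72 h; a higher number here means a weaker inhibitor, a lower number a stronger inhibitor:
- compound 1 `COc1cc(-n2cnc3ccc(-c4cc(F)ccc4F)cc32)cc(OC)c1OC`: 6590 nM
- compound 2 `COc1cc(-n2cnc3ccc(-c4cccc([N+](=O)[O-])c4)cc32)cc(OC)c1OC`: 380 nM
- compound 3 `COc1cc(-n2cnc3ccc(-c4ccc(O)cc4)cc32)cc(OC)c1OC`: > 10000 nM

Compound 3 gives only a limit, (the limit of > 10000 nM in this assay, at which 1 of the 3 values shown sits), so no number is known for it. The steps to it are an at least 1.5-fold higher number from compound 1 to compound 3 (0.18 log units; that floor lies within the scatter) and an at least 26-fold higher number from compound 2 to compound 3 (1.42 log units; beyond the scatter), the second beyond the scatter. Compound 4 `COc1cc(-n2cnc3ccc(-c4ccc(C)cc4)cc32)cc(OC)c1OC` differs from compound 3 in one place: methyl in place of hydroxy on an aromatic carbon. For the measured compounds named here, no measured step swaps hydroxy for methyl, so the measured steps, including a 17-fold lower number from compound 1 to compound 2 (1.24 log units; beyond the scatter), give no direct guide; they show only how widely this position moves the read-out. Compound 4 is therefore expected to read below the limit, with the step estimated at an at least 2.0-fold lower number from compound 3 to compound 4 (0.30 log units; that floor lies within the scatter). For compound 4 the expected value in this assay is 5000 nM, estimated between 1500 nM and 15000 nM.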

Compound 4, half-maximal inhibitory concentration: 200 nM
Estimate against measurement, compound 4: 25-fold (1.40 log units) above; the measured number lies below the stated range.
By their numbers in this assay, from the lowest: compounds 4 and 2 (each within the scatter of the next); then compound 1. At a limit, above all of these: compound 3.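

A change of one heavy atom, para to a large group, gives an at least 50-fold lower number from compound 3 to compound 4 (1.69 log units; beyond the scatter) in this assay, so a single atom at this place can separate a weak compound from a strong one. That step is only a floor, as compound 3 stands at a limit: the limit of > 10000 nM in this assay, at which 1 of the 4 values shown sits. The 4-methylphenyl and 3-nitrophenyl groups cannot be told apart here, with a 1.9-fold lower number from compound 2 to compound 4 (0.28 log units; within the scatter), whereas the 2,5-difluorophenyl group trails, with a 33-fold lower number from compound 1 to compound 4 (1.52 log units; beyond the scatter).

From the compounds shown here alone, whether the gain comes from losing hydroxy or from adding methyl stays open. A methoxy group, an amine or a longer chain such as ethyl at this place would help to separate the two.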